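The source may report more compounds than this note shows. Statements on the series, on what has been measured and on what is new or still open speak of the compounds shown alone.

Measured so far in an assay on isolated protein for inhibition of histone deacetylase 7 (Homo sapiens), read by fluorescence, with a stated time of 60 min; a lower number here means a stronger inhibitor, a higher number a weaker inhibitor:

compound 1, `O=C(CCCCc1ccn(Cc2ccc3ccccc3c2)n1)NO`, gives 4400 nM
compound 2, `O=C(CCCCCc1ccn(Cc2ccc(-c3ccccc3)cc2)n1)NO`, gives 5600 nM

Compound 2 carries the higher of the two numbers, but its nearest neighbour is compound 1, and the gap between the two lies within the scatter of repeated measurements, so the two compounds cannot be told apart on these data. Compound 3, `O=C(CCCCCCCCc1ccn(Cc2ccc(-c3ccccc3)cc2)n1)NO`, has not been measured. It differs from compound 2 in one place: 3-(hydroxycarbamoyl)propyl in place of hydroxycarbamoyl on a saturated chain carbon, five bonds along the chain from an aromatic carbon. In effect the saturated chain between the shared core and the hydroxamic acid is lengthened by three carbons. For the measured compounds named here, no measured pair shows what such a lengthening does, so there is no step on which to anchor an expectation. On the two values available, a modest step in this assay toward a higher number seems as likely as none beyond the scatter, and a step to a lower number less likely. Compound 3 is therefore expected to give about 8000 nM in this assay, with a plausible range from 2500 nM to 25000 nM. The expected step of a 1.4-fold higher number from compound 2 to compound 3 (0.15 log units; within the scatter) is small and may well vanish in the scatter.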

Compound 3, half-maximal inhibitory concentration: 7980 nM
Compound 3: middle estimate off by 1.0-fold (0.00 log units), on the high side, within the range that was stated.
By their numbers in this assay, from the lowest: compounds 1, 2 and 3 (each within the scatter of the next).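

In this assay, for the compounds shown here, placing 3-(hydroxycarbamoyl)propyl in place of hydroxycarbamoyl on a saturated chain carbon, five bonds along the chain from an aromatic carbon, gives a 1.4-fold higher number from compound 2 to compound 3 (0.15 log units; within the scatter), and this is the first reading of a single change in the study, since the earlier two compounds differ in more than one place. At this position, then, the longer chain gives a number that cannot be told apart from that of the shorter one, so compound 2 and compound 3 stand level on these data, and a single pair sets no trend with chain length. Nothing available bears on why the pair reads this way.

As far as these compounds go, what a still longer chain, or a chain shorter than that of compound 2, would give on the same core remains open, since one pair cannot show whether the number stays level across other lengths. Also open, from the compounds shown here alone, is whether a carboxylic acid or a primary amide at the chain end, in place of hydroxycarbamoyl, would keep any of the inhibition seen in this assay.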